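Compound 4: a dichlorophenyl swap on compound 1

The compounds below may be only part of what the source reports. "The series", "measured", "known", "first", "only" and "open" are said of these compounds alone.

In a functional assay on A549 cells (Homo sapiens) for antiproliferative activity, read by MTT assay, with a stated time of 48 h (a lower number here means a stronger inhibitor, a higher number a weaker inhibitor), compound 1 `COc1ccccc1N1CCN(C(=O)/C=C/c2ccc(O)c(O)c2)CC1` gives 0.98 ug/mL, compound 2 `COc1cccc(N2CCN(C(=O)/C=C/c3ccc(O)c(O)c3)CC2)c1` gives 1.27 ug/mL and compound 3 `O=C(/C=C/c1ccc(O)c(O)c1)N1CCN(c2cccc(C(F)(F)F)c2)CC1` gives 1.74 ug/mL. Compound 1 stands within the scatter of both others, so the three are not separated.

Compound 4 `O=C(/C=C/c1ccc(O)c(O)c1)N1CCN(c2ccc(Cl)c(Cl)c2)CC1` differs from compound 1 in one place: 3,4-dichlorophenyl in place of 2-methoxyphenyl on an amine nitrogen in a ring. In words, 3,4-dichlorophenyl stands in place of 2-methoxyphenyl on an amine nitrogen in a ring.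

Within the data shown here, two measured steps bear on this change: a 1.3-fold higher number from compound 1 to compound 2 (0.11 log units; within the scatter) and a 1.4-fold higher number from compound 2 to compound 3 (0.14 log units; within the scatter). Among the measured compounds shown here, both are small, but no measured compound carries chlorine, so they guide the expectation only loosely. No step beyond the scatter is therefore expected in this assay, in either direction. Compound 3 also lacks methoxy, and its 1.74 ug/mL sets the middle of the estimate. The expected change is a 1.6-fold higher number from compound 1 to compound 4 (0.21 log units; within the scatter). For compound 4 the estimated value is 1.6 ug/mL, with an expected range from 0.7 ug/mL to 3.5 ug/mL.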

Compound 4, half-maximal inhibitory concentration: 1.74 ug/mL
For compound 4 the middle estimate is 1.1-fold (0.04 log units) below the measured one; the range from low to high includes it.
By their numbers in this assay, from the lowest: compounds 1, 2, 3 and 4 (each within the scatter of the next).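

In this assay the first chlorine-bearing compound gives a 1.8-fold higher number from compound 1 to compound 4 (0.25 log units; within the scatter) and a 1.4-fold higher number from compound 2 to compound 4 (0.14 log units; within the scatter) and so is not separated from either methoxy compound. On an amine nitrogen in a ring, 3,4-dichlorophenyl can therefore stand in place of either methoxyphenyl group without a step beyond the scatter. This holds although the entering group has 2 chlorine and 0 hydrogen-bond acceptors, and the 2-methoxyphenyl group it replaces has 1 oxygen and 1 hydrogen-bond acceptor. No measurement on these groups accompanies this result, and the data give no explanation of it.

Every compound shown carries a substituted phenyl at this place, so the limits of the change remain undefined. Going by these compounds, whether an amine or a carboxylic acid on that phenyl, or a longer chain in place of it, would give a step beyond the scatter remains open.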